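Removing the Drawn Configuration at the Ring Stereocentre

A few compounds are considered here, and "the series" means these few. Any claim that something is new, unique, unknown or untested is made for them only; others in the source may bear on it.

Compound 1 `CCCc1c(OCCCOc2ccc(C(N)=O)c(OC)c2CCC)ccc2c1OC(C(=O)O)CC2` and compound 2 `CCCc1c(OCCCOc2ccc(C(=O)NC)c(OC)c2CC2CC2)ccc2c1O[C@@H](CCC(=O)O)CC2` share the same core and differ in several places at once. In an assay on isolated protein for inhibition of leukotriene B4 receptor 1 (Homo sapiens) (a higher number here means a weaker inhibitor, a lower number a stronger inhibitor), compound 1 gives 2.4 nM, and compound 2 gives 8.5 nM, the higher of the two numbers, with the gap between them lying beyond the usual scatter. Compound 3 `CCCc1c(OCCCOc2ccc(C(=O)NC)c(OC)c2CC2CC2)ccc2c1OC(CCC(=O)O)CC2` has not yet been measured and is the partner of compound 2 in the step followed here. The change between them is the two compounds have the same atoms and bonds; at least one stereo element is drawn with a configuration in one of them and without one in the other: 1 of 1 stereo elements differ; a stereocentre at a saturated ring carbon is drawn R in compound 2 and without a configuration in compound 3. Within the data shown here, no step between measured compounds that differ in one place is available, so the expectation rests on the two values alone. Compound 2 is drawn with a single configuration and compound 3 without one; a modest step toward a higher number is expected, a 1.5-fold higher number from compound 2 to compound 3 (0.18 log units; within the scatter). Compound 3 is therefore estimated to give 13 nM in this assay, with a range from 6 nM to 30 nM.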

Compound 3, half-maximal inhibitory concentration: 10.9 nM
The estimate for compound 3 lay 1.2-fold (0.08 log units) above the measured number; the range from low to high includes it.
By their numbers in this assay, from the lowest: compound 1; then compounds 2 and 3 (each within the scatter of the next).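

Among these compounds, this is the only pair so far that differs in one place, and it gives the first direct reading at the saturated ring carbon. In this assay the step is a 1.3-fold higher number from compound 2 to compound 3 (0.11 log units; within the scatter), so at this stereocentre a drawn R configuration and no drawn configuration cannot be told apart by their numbers. Nothing else separates the two structures, and the comparison therefore bears on this feature alone: the fact that one of compounds 2 and 3 is drawn with a defined configuration and the other without, at the place where they differ

The compounds shown do not say how a form drawn S would read at this carbon, nor how a tetrazole in place of the carboxylic acid would fare. The gap between compound 1 and compound 2 also remains unassigned, as those two differ in several places at once, including the primary amide against the N-methyl amide.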